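Nitrile replaced by methylsulfanyl chain in a phenol series

The source may hold more compounds than are shown below. What is called first, only, known or untested is meant among the compounds shown, and "the series" means these compounds.

Measured compounds in an assay on isolated protein for binding affinity to leukotriene B4 receptor 1 (Homo sapiens), tested at 1 uM; on this read-out lower numbers stand for less inhibition and higher numbers for more inhibition at the one concentration tested (going by the name of the read-out):
- compound 1 `C=CCc1cc(C(C)=O)c(O)cc1OCCCCCC#N`: 41%
- compound 2 `CCc1cc(C(C)=O)c(O)cc1OCCCCC(C)(C)C#N`: 30%
- compound 3 `C=CCc1cc(C(C)=O)c(O)cc1OCCCCCC(C)(C)O`: 60%

Compound 2 stands lowest of the three, with compound 1 nearest and compound 3 furthest; both gaps are beyond the scatter. Compound 4 `CCc1cc(C(C)=O)c(O)cc1OCCCCCCSC` has not yet been measured. It differs from compound 2 by 2-(methylsulfanyl)ethyl in place of 1-cyano-1-methylethyl on a saturated chain carbon, four bonds along the chain from an oxygen on an aromatic ring.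

Within the data shown here, no measured step carries this exact change. Among the measured compounds shown here, the one step available, a number 19 percentage points higher from compound 1 to compound 3 (beyond the scatter), removes a cyano group at a neighbouring chain position and adds a hydroxyl-bearing group, and it is the only guide to what losing the nitrile does here. It points modestly upward, but the entering group in compound 4 carries no hydroxyl, so only part of that rise is expected to carry over. The expected step is therefore a number 10 percentage points higher from compound 2 to compound 4 (within the scatter), a small increase in this assay with wide uncertainty. For compound 4 the estimate in this assay is 40%, within 22% to 58%.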

Compound 4, a percentage reported as inhibition, at one concentration (the size of the read-out at that concentration, not a potency): 14%
Beside the measured number, compound 4's estimate is 26 percentage points above it; the measured number lies below the stated range.
By their numbers in this assay, from the lowest: compound 4; then compound 2; then compound 1; then compound 3.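

In this assay, 2-(methylsulfanyl)ethyl in place of 1-cyano-1-methylethyl on a saturated chain carbon, four bonds along the chain from an oxygen on an aromatic ring, gives a number 16 percentage points lower from compound 2 to compound 4 (beyond the scatter). The other step that leaves the nitrile behind, a number 19 percentage points higher from compound 1 to compound 3 (beyond the scatter), runs the opposite way, so in these two pairs losing the nitrile does not alone set the direction; the entering group and the place on the chain both differ between the steps. Nothing shown gives a reason for the drop.

Among these compounds, still open is whether the drop follows from the sulfur-bearing chain or from the loss of the branched nitrile group, as the one step changes both. A carboxylic acid or an amine at this chain end, or 1-hydroxy-1-methylethyl at this same place, would help separate the two.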